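The compounds below may be only part of what the source reports. "The series", "measured", "known", "first", "only" and "open" are said of these compounds alone.

Measured so far in a functional assay on the whole organism with Mus musculus as the target; a higher number here means that more compound is needed for the effect, a lower number that less compound is needed:
compound 1 `CCCCCOc1ccc2nncn2n1`: 39.4 mg/kg
compound 2 `Cc1cccc(Oc2ccc3nncn3n2)c1`: > 100 mg/kg
compound 3 `Cc1ccc(Oc2ccc3nncn3n2)cc1`: > 100 mg/kg

Within the data shown here, compound 1 is the only member with a number. The result for compound 2 is only a limit, > 100 mg/kg. The result for compound 3 is likewise only a limit, > 100 mg/kg. Among the measured compounds shown here, compound 3 therefore stands at the limit of > 100 mg/kg in this assay, at which 2 of the 3 values shown sit, and no measured step connects it to compound 1. Compound 4 `COc1ccc(Oc2ccc3nncn3n2)cc1` is unmeasured; it differs from compound 3 by methoxy in place of methyl on an aromatic carbon. For the measured compounds named here, no step between measured compounds exists in this assay, so no direction beyond the scatter can be drawn from the data. Since compound 3 itself gives > 100 mg/kg, a limit is again the most likely outcome. Compound 4 is expected at 150 mg/kg, within 50 mg/kg to 450 mg/kg. The step from compound 3 to compound 4 is estimated as a step that the limit leaves unreadable from compound 3 to compound 4.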

Compound 4, dose for half-maximal effect: > 100 mg/kg
Compound 4 was reported as a limit; the forecaster's own chance of this, stated with the estimate: 70%; the middle value does not contradict the limit.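

Compound 3 and compound 4 both give only a limit in this assay, so no step between them can be read: the limit of > 100 mg/kg in this assay, at which 3 of the 4 values shown sit.

Going by these compounds, whether methoxy in place of methyl on an aromatic carbon shifts the dose in this assay stays open.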